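Chloro in Place of Fluoro: Expected Cytotoxicity of Compound 4

A few compounds are considered here, and "the series" means these few. Any claim that something is new, unique, unknown or untested is made for them only; others in the source may bear on it.

Measured so far:
compound 1 `CCN(CC)CCn1cnnc1-c1cc(Oc2ccc(NC(=O)Nc3ccc(Cl)c(C(F)(F)F)c3)cc2F)ccn1`, 6730 nM
compound 2 `CCN(CC)CCn1cnnc1-c1cc(Oc2ccc(NC(=O)Nc3ccccc3C(F)(F)F)cc2F)ccn1`, 23500 nM
compound 3 `CCN(CC)CCn1cnnc1-c1cc(Oc2ccc(NC(=O)Nc3ccc(F)c(F)c3)cc2F)ccn1`, > 50000 nM

In an ADME assay on WI-38 cells (Homo sapiens) for cytotoxicity, read by MTT assay, with a stated time of 72 h (a lower number here means a stronger inhibitor, a higher number a weaker inhibitor), compound 1 gives 6730 nM and compound 2 gives 23500 nM. Compound 3 reaches only the limit of this assay, > 50000 nM, and so stands at the weak end of the three. Its steps, an at least 7.4-fold higher number from compound 1 to compound 3 (0.87 log units; beyond the scatter) and an at least 2.1-fold higher number from compound 2 to compound 3 (0.32 log units; beyond the scatter), both lie beyond the scatter, as does a 3.5-fold higher number from compound 1 to compound 2 (0.54 log units; beyond the scatter); in every case the aryl group on the amide-type nitrogen was changed, and the ring carrying chloro together with trifluoromethyl gave the lowest number.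

Compound 4 `CCN(CC)CCn1cnnc1-c1cc(Oc2ccc(NC(=O)Nc3ccc(F)c(Cl)c3)cc2F)ccn1` differs from compound 3 by chloro in place of fluoro on an aromatic carbon. Since only a limit is known for compound 3, the step cannot be sized from the data; a chloro-bearing ring moves toward compound 1, so a modest drop in the number is expected, an at least 1.4-fold lower number from compound 3 to compound 4 (0.15 log units; that floor lies within the scatter). Compound 4 is therefore estimated at 35000 nM, between 12000 nM and 80000 nM, with a fair chance that only a limit is reported.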

Compound 4, half-maximal inhibitory concentration: 28700 nM
Compound 4: middle estimate off by 1.2-fold (0.09 log units), on the high side; low and high end bracket the measured number.
By their numbers in this assay, from the lowest: compound 1; then compounds 2 and 4 (each within the scatter of the next). At a limit, above all of these: compound 3.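

Chloro in place of fluoro here, ortho to a fluoro group, brings the ring closer to compound 1 and gives a measured number rather than a limit (an at least 1.7-fold lower number from compound 3 to compound 4 (0.24 log units; that floor lies within the scatter)). Compound 4 cannot be told apart from compound 2 (a 1.2-fold higher number from compound 2 to compound 4 (0.09 log units; within the scatter)), while the 4-chloro-3-(trifluoromethyl)phenyl ring keeps a clear lead (a 4.3-fold higher number from compound 1 to compound 4 (0.63 log units; beyond the scatter)). The true size of the chloro step stays unread, since compound 3 marks only a limit: the limit of > 50000 nM in this assay, at which 1 of the 4 values shown sits.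

On these data alone, whether bromo or methyl at this position would lower the number further remains open. So does the effect of a lone chloro without the fluoro group.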